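Swapping Methoxy for Acetyl at One Ring Position

The compounds below may be only part of what the source reports. "The series", "measured", "known", "first", "only" and "open" are said of these compounds alone.

Measured compounds:
compound 1 `C=C(C)c1ccccc1OC(C)C1=NCCN1` gives 871 nM
compound 2 `CC(C)Oc1ccccc1OC(C)C1=NCCN1` gives 1580 nM
compound 3 `COc1ccccc1OC(C)C1=NCCN1` gives 871 nM

Three compounds share one core and differ only in the group carried on one aromatic carbon; all were tested in an assay on CHO cells for displacement of a labelled ligand from Alpha-2B adrenergic receptor (Homo sapiens); on this read-out higher numbers stand for weaker inhibition and lower numbers for stronger inhibition. Compound 3 stands level with compound 1, and the two together hold the lowest numbers of the three, though every gap here is within the scatter: no change at the digits printed from compound 1 to compound 3 (within the scatter), a 1.8-fold higher number from compound 1 to compound 2 (0.26 log units; within the scatter) and a 1.8-fold lower number from compound 2 to compound 3 (0.26 log units; within the scatter).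

Compound 4 `CC(=O)c1ccccc1OC(C)C1=NCCN1` is the next step: acetyl in place of methoxy on an aromatic carbon. Among the compounds with values here, no measured step exchanges an alkoxy group for a ketone at this position, so the only guidance is that the three changes already made there — alkene, isopropoxy, methoxy — all left the number within the scatter. The reasonable expectation is therefore a step of a 1.1-fold higher number from compound 3 to compound 4 (0.06 log units; within the scatter), with no direction beyond the scatter claimed. Compound 4 is estimated at 1000 nM, in a range from 300 nM to 3500 nM.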

Compound 4, inhibition constant: 6170 nM
Estimate against measurement, compound 4: 6.2-fold (0.79 log units) below, outside the stated range (above it).
By their numbers in this assay, from the lowest: compounds 1, 3 and 2 (each within the scatter of the next); then compound 4.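

This position is not indifferent to the group it carries: in this assay putting acetyl on this aromatic carbon gives a 7.1-fold higher number from compound 3 to compound 4 (0.85 log units; beyond the scatter) and likewise a 3.9-fold higher number from compound 2 to compound 4 (0.59 log units; beyond the scatter) as well as a 7.1-fold higher number from compound 1 to compound 4 (0.85 log units; beyond the scatter) and so weaker inhibition in each comparison. Within the data shown here, the 1-methylethenyl, isopropoxy and methoxy groups all lie within the scatter of one another, so acetyl is the first group here whose number can be told apart from the others. Nothing available explains why acetyl stands apart from these three groups.

On these data alone, it remains open whether the weaker inhibition is particular to acetyl or would also appear with other groups at this position, such as an amine or a carboxylic acid. How a longer chain in place of the methyl of the acetyl group would read is also unknown.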